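One Inverted Stereocentre: From Compound 2 to Compound 4

The source may report more compounds than this note shows. Statements on the series, on what has been measured and on what is new or still open speak of the compounds shown alone.

- compound 1 `CO[C@@H]1[C@H]2OC(=O)C[C@H]2O[C@@H]1C(=O)c1ccccc1`: 8970 nM
- compound 2 `CO[C@@H](c1ccccc1)[C@H]1O[C@@H]2CC(=O)O[C@@H]2[C@H]1O`: 12600 nM
- compound 3 `CO[C@@H]1[C@H]2OC(=O)C[C@H]2O[C@@H]1[C@H](O)c1ccccc1`: 24900 nM
- compound 4 `CO[C@H](c1ccccc1)[C@H]1O[C@@H]2CC(=O)O[C@@H]2[C@H]1O`: not yet measured

These three measured compounds were all tested in a functional assay on Jurkat cells (Homo sapiens) for inhibition, read by MTT assay, with a stated time of 72 h; on this read-out lower numbers stand for stronger inhibition and higher numbers for weaker inhibition. There, compound 2 gives 12600 nM, a value within the scatter of those of both compound 1 and compound 3, and it sits in the middle of the three numbers. Compound 4 keeps the same atoms and bonds as compound 2, and the two differ only as follows: the two compounds have the same atoms and bonds and differ only in configuration as drawn: 1 of 5 stereo elements differ; a stereocentre at a saturated chain carbon is drawn S in compound 2 and R in compound 4. Within the data shown here, no measured pair shows what such an inversion does in this assay, so the data offer no direct guide to its size or direction. The only available frame is the narrow span of the measured values, from compound 1 at 8970 nM to compound 3 at 24900 nM. The expected outcome is a 1.1-fold lower number from compound 2 to compound 4 (0.02 log units; within the scatter), with no change beyond the scatter and no favoured direction. For compound 4 the estimated value is 12000 nM, with an expected range from 5000 nM to 30000 nM.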

Compound 4, half-maximal inhibitory concentration: 15600 nM
Estimate against measurement, compound 4: 1.3-fold (0.11 log units) below; the measured number falls inside the stated range.
By their numbers in this assay, from the lowest: compounds 1, 2, 4 and 3 (each within the scatter of the next, the first and the last beyond it).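

In this assay, among these compounds, the earlier compounds offered no pair that isolated a single change, and this step is the first to do so, with nothing else varying between the two structures: the fact that compounds 2 and 4 differ only in the configuration as drawn. Inverting the stereocentre at the saturated chain carbon gives a 1.2-fold higher number from compound 2 to compound 4 (0.09 log units; within the scatter) and thus leaves the read-out unchanged beyond the scatter. At this position, therefore, the configuration as drawn has no effect that this assay can resolve, although that finding rests on one pair alone.

As far as these compounds go, whether the inversion would remain this silent with a different group on that carbon, such as an amine or a carboxylic acid, remains open. The compounds shown also leave open whether a longer chain at this position would alter the read-out in either configuration.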